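From Propyl to Isopropyl on a Double-Bonded Nitrogen

The source may report more compounds than this note shows. Statements on the series, on what has been measured and on what is new or still open speak of the compounds shown alone.

Of the compounds shown here, three sharing closely related structures have been measured so far in a functional assay (aorta) for inhibition, with Rattus norvegicus as the target; a lower number here means a stronger inhibitor, a higher number a weaker inhibitor. Compound 1 `C/N=C(\S)[C@]1(c2cc(Cl)cc(Cl)c2)CCCC[S+]1[O-]` gives 400 nM, compound 2 `CC/N=C(\S)[C@]1(c2cccnc2)CCCC[S+]1[O-]` gives 300 nM, and compound 3 `CCC/N=C(\S)[C@]1(c2cccnc2)CCCC[S+]1[O-]` gives 600 nM. Compound 3 therefore lies within the usual scatter of both other compounds, so these numbers set no firm order among them.

The next compound, compound 4 `CC(C)/N=C(\S)[C@]1(c2cccnc2)CCCC[S+]1[O-]`, has the same atoms as compound 3, joined differently: isopropyl in place of propyl on a double-bonded nitrogen.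

Within the data shown here, only one measured step bears directly on this change. It is a 2.0-fold higher number from compound 2 to compound 3 (0.30 log units; within the scatter), produced by adding methyl to a saturated chain carbon, two bonds along the chain from a double-bonded nitrogen, and it lies within the scatter. Compound 1 differs from the others in more than one place, so it offers no clean comparison. Among the measured compounds shown here, no compound with isopropyl has been measured yet, which leaves the direction of any change open.

A large change in this assay is therefore not expected. The expected step is a 1.3-fold lower number from compound 3 to compound 4 (0.12 log units; within the scatter), which would not go beyond the scatter. For compound 4, the estimated value is 450 nM, with an expected range from 170 nM to 1200 nM.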

Compound 4, concentration for 90% inhibition: 10000 nM
Beside the measured number, compound 4's estimate is 22-fold (1.35 log units) below it, outside the stated range (above it).
By their numbers in this assay, from the lowest: compounds 2, 1 and 3 (each within the scatter of the next); then compound 4.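

In this assay, the group on the double-bonded nitrogen cannot be rearranged freely: isopropyl in place of propyl keeps the same atoms yet gives a 17-fold higher number from compound 3 to compound 4 (1.22 log units; beyond the scatter), so how these atoms are joined matters here as well as which atoms are present. The place of an added methyl also makes a difference, since on the saturated chain carbon bound to the double-bonded nitrogen it gives a 33-fold higher number from compound 2 to compound 4 (1.52 log units; beyond the scatter), whereas two bonds along the chain from that nitrogen it gives a 2.0-fold higher number from compound 2 to compound 3 (0.30 log units; within the scatter), a step within the scatter. Nothing available here explains why the rearrangement weakens inhibition so sharply.

The compounds shown leave open whether any further group on the carbon bound to this nitrogen is tolerated, a question that cyclopropyl or tert-butyl would test, and how far a straight chain can grow, which butyl would test. They also leave open whether isopropyl has the same large effect with the 3,5-dichlorophenyl group of compound 1 in place of the ring carried by compound 4.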